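Changing the aryl group on the ring nitrogen

The source may report more compounds than this note shows. Statements on the series, on what has been measured and on what is new or still open speak of the compounds shown alone.

Compound 1 `CCCCN(CC)c1cc(C)nc2c1NC(=O)CN2c1ccc(C)cc1Cl` was tested in an assay on HEK-293T cells for displacement of a labelled ligand from corticotropin-releasing factor receptor 1 (Homo sapiens), read by scintillation counting, with a stated time of 2 h (a lower number here means a stronger inhibitor, a higher number a weaker inhibitor), where compound 1 gives 4.4 nM. Among the two numbers measured so far this is the higher one; the only other measured compound, compound 2 `CCCCN(CC)c1cc(C)nc2c1NC(=O)CN2c1ccc(Br)cc1Br`, gives 1.3 nM in this assay. Going by the values given here, the single measured step, a 3.4-fold lower number from compound 1 to compound 2 (0.53 log units; beyond the scatter), shows that exchanging the aromatic group on the ring nitrogen can shift the number modestly. Compound 3 `CCCCN(CC)c1cc(C)nc2c1NC(=O)CN2c1ccc(Br)cc1CC` has not yet been measured. It differs from compound 1 in one place: 4-bromo-2-ethylphenyl in place of 2-chloro-4-methylphenyl on a nitrogen on an aromatic ring in a ring. Among the compounds with values here, the step to compound 2 bears on this, because compound 2 also carries bromine on that aromatic group and gave 1.3 nM; the ethyl group, however, is new and no measured step covers it. Compound 3 is therefore expected to give about 3 nM, estimated to lie between 1 nM and 9 nM. The expected step of a 1.5-fold lower number from compound 1 to compound 3 (0.17 log units; within the scatter) would be small, close to the scatter.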

Compound 3, inhibition constant: 2.5 nM
Estimate against measurement, compound 3: 1.2-fold (0.08 log units) above, within the range that was stated.
By their numbers in this assay, from the lowest: compounds 2, 3 and 1 (each within the scatter of the next, the first and the last beyond it).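

In this assay, ethyl in place of bromo on an aromatic carbon gives a 1.9-fold higher number from compound 2 to compound 3 (0.28 log units; within the scatter) so this exchange has no effect that can be told apart from repeat-measurement noise. The other new step, a 1.8-fold lower number from compound 1 to compound 3 (0.25 log units; within the scatter) also leaves 4-bromo-2-ethylphenyl indistinguishable from 2-chloro-4-methylphenyl, so compound 3 sits within the scatter of both neighbours, even though compound 1 and compound 2 differ by more than the scatter. No independent measurement is available to explain these numbers.

The compounds shown leave open whether a methoxy group or a longer chain such as propyl in place of ethyl would keep the number in this range. They also leave open what a pyridine ring in place of the substituted phenyl on the ring nitrogen would do.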